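The source may report more compounds than this note shows. Statements on the series, on what has been measured and on what is new or still open speak of the compounds shown alone.

Measured compounds:

Compound 1, `CCCCOc1ccc(C(=O)/C=C/c2c(OC)cccc2OC)cc1`: in a functional assay (Homo sapiens) for inhibition (a higher number here means a weaker inhibitor, a lower number a stronger inhibitor), compound 1 gives 127000 nM.
Compound 2, `CCCCOc1ccc(C(=O)/C=C/c2cc(OC)cc(OC)c2)cc1`: in this assay compound 2 gives 52000 nM.
Compound 3, `COc1cccc(OC)c1/C=C/C(=O)c1ccc(O)cc1`: in this assay compound 3 gives 60000 nM.

All three compounds share the same overall framework, but compound 1 and compound 2 carry their two methoxy groups in different arrangements; the difference between the two cores is not broken down here. What the values show is that compound 2 has the lower number of the two and that this gap lies beyond the usual scatter, while compound 2 and compound 3 lie within the scatter of each other.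

Compound 3 differs from compound 1 by one change, (hydrogen in place of butyl on an oxygen on an aromatic ring). This change gave a 2.1-fold lower number from compound 1 to compound 3 (0.33 log units; beyond the scatter), a modest step that nonetheless exceeds the scatter.

Compound 4, `COc1cc(/C=C/C(=O)c2ccc(O)cc2)cc(OC)c1`, is not yet measured. It relates to compound 2 by the same change, (hydrogen in place of butyl on an oxygen on an aromatic ring). The place is the same in both pairs, an oxygen on an aromatic ring whose other neighbour is an aromatic carbon, so the change is the same one seen before, made on the core of compound 2 rather than that of compound 1. Resting on compound 1 moving to compound 3 by a 2.1-fold lower number from compound 1 to compound 3 (0.33 log units; beyond the scatter), a step of similar size is expected from compound 2 to compound 4 in this assay, namely a 2.1-fold lower number from compound 2 to compound 4 (0.32 log units; beyond the scatter). Given that compound 2 gives 52000 nM, compound 4 is estimated at 25000 nM, with a likely range from 12000 nM to 60000 nM.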

Compound 4, half-maximal inhibitory concentration: 14000 nM
For compound 4 the middle estimate is 1.8-fold (0.25 log units) above the measured one; the range from low to high includes it.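

Replacing butoxy with hydroxy on the core of compound 2 gave a 3.7-fold lower number from compound 2 to compound 4 (0.57 log units; beyond the scatter) in this assay, so the direction seen on the core of compound 1 recurred on a second core. The two steps can be set side by side, and the gap between their sizes does not separate them: the same change on two cores in this assay, a 2.1-fold lower number (0.33 log units; beyond the scatter) from compound 1 to compound 3 and a 3.7-fold lower number (0.57 log units; beyond the scatter) from compound 2 to compound 4, 1.8-fold (0.24 log units) apart, within the scatter of two such steps. Across these two cores, the change therefore carried over in direction and, within the scatter, in size, but this does not show that it acts more strongly on one core than on the other. Two pairs are too few to support a rule for the whole series.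

The compounds shown leave open how the number in this assay would respond to other groups on that oxygen, such as an ethyl group, a longer chain such as octyl, or a chain ending in a carboxylic acid, since only butyl and hydrogen are compared here. They also leave open whether the same step would appear on a core that carries something other than the two methoxy groups, such as an amine or a halogen like chlorine.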